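Compound 4: pyridin-4-yl at the assay limit

A few compounds are considered here, and "the series" means these few. Any claim that something is new, unique, unknown or untested is made for them only; others in the source may bear on it.

Compound 1 `CC(C)(C)n1cc2c(n1)C(=O)CC1(CCN(C(=O)c3cc(-c4ccc(Br)cc4)nc4ccccc34)CC1)O2` gives > 10000 nM
Compound 2 `CC(C)(C)n1cc2c(n1)C(=O)CC1(CCN(C(=O)c3cc(-c4ccc(N)cc4)nc4ccccc34)CC1)O2` gives 4960 nM
Compound 3 `CN(C)c1ccc(-c2cc(C(=O)N3CCC4(CC3)CC(=O)c3nn(C(C)(C)C)cc3O4)c3ccccc3n2)cc1` gives > 10000 nM

All three were read in a functional assay on MDA-MB-231 cells (Homo sapiens) for inhibition, read by MTT assay, with a stated time of 72 h (a lower number here means a stronger inhibitor, a higher number a weaker inhibitor), and only compound 2 gives a true number. Compound 1 carries a limit and not a number. Compound 3 likewise stands at the limit of > 10000 nM in this assay, at which 2 of the 3 values shown sit, and so has no exact place in the series.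

Compound 4 `CC(C)(C)n1cc2c(n1)C(=O)CC1(CCN(C(=O)c3cc(-c4ccncc4)nc4ccccc34)CC1)O2` carries pyridin-4-yl in place of the 4-(dimethylamino)phenyl of compound 3 (pyridin-4-yl in place of 4-(dimethylamino)phenyl on an aromatic carbon). The measured steps only swap groups on that aromatic substituent. Amino in place of bromo gives an at least 2.0-fold lower number from compound 1 to compound 2 (0.30 log units; that floor lies within the scatter) and dimethylamino in place of amino gives an at least 2.0-fold higher number from compound 2 to compound 3 (0.30 log units; that floor lies within the scatter) while dimethylamino in place of bromo gives a step that the two limits leave unreadable from compound 1 to compound 3 and none of them introduces pyridin-4-yl. Within the data shown here, with compound 2 at 4960 nM as the sole number, no step beyond the scatter is expected in this assay. Another limit would be no surprise. The expected change is an at least 1.1-fold lower number from compound 3 to compound 4 (0.04 log units; that floor lies within the scatter) and it rests on thin evidence. Compound 4 is estimated at 9000 nM (expected range 3000 nM to 27000 nM).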

Compound 4, half-maximal inhibitory concentration: 1650 nM
For compound 4 the middle estimate is 5.5-fold (0.74 log units) above the measured one; measured number below the stated range.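

In this assay, putting pyridin-4-yl at this position in place of a substituted phenyl ring gives an at least 6.0-fold lower number from compound 3 to compound 4 (0.78 log units; beyond the scatter), a 3.0-fold lower number from compound 2 to compound 4 (0.48 log units; beyond the scatter) and an at least 6.0-fold lower number from compound 1 to compound 4 (0.78 log units; beyond the scatter), which makes compound 4 the most potent of the four. Among these compounds, the earlier swaps of groups on the phenyl ring gave no step that can be read as beyond the scatter, so this is the first change here that clearly moves the number. Two of these steps are floors and not full sizes, as compound 1 and compound 3 each carry only a limit: the limit of > 10000 nM in this assay, at which 2 of the 4 values shown sit.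

The compounds shown do not separate the effect of the ring nitrogen from the effect of losing the substituent on the phenyl ring. An unsubstituted phenyl or a pyridin-3-yl group at this position would bear on that question.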